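The source may report more compounds than this note shows. Statements on the series, on what has been measured and on what is new or still open speak of the compounds shown alone.

Working notes on the series.

Compound 1 `O=C1O[C@H]([C@@H](O)Cn2cc(CNS(=O)(=O)c3ccc(Cl)cc3F)nn2)C(OCc2ccccc2)=C1OCc1ccccc1` is the lowest of the two numbers obtained in a functional assay on MCF7 cells (Homo sapiens) for antiproliferative activity, read by MTT assay, with a stated time of 72 h; on this read-out higher numbers stand for weaker inhibition and lower numbers for stronger inhibition: compound 1 gives 3390 nM. Compound 2 `O=C1O[C@H]([C@@H](O)Cn2cc(-c3cc(C(F)(F)F)cc(C(F)(F)F)c3)nn2)C(OCc2ccccc2)=C1OCc1ccccc1`, which carries a bis(trifluoromethyl)phenyl group on the triazole in place of the sulfonamide arm, gives 45900 nM in this assay, a gap from compound 1 that lies beyond the scatter. Compound 3 `O=C1O/C(=C\Cn2cc(-c3cc(C(F)(F)F)cc(C(F)(F)F)c3)nn2)C(OCc2ccccc2)=C1OCc1ccccc1` is the exocyclic alkene analogue of compound 2. In this assay compound 3 reaches only a limit of the assay, > 100000 nM, and no number; the series as a whole sits at the limit of > 100000 nM in this assay, at which 1 of the 3 values shown sits, for one of its three values.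

Compound 4 `O=C1O[C@H]([C@@H](O)Cn2cc(CNS(=O)(=O)c3ccc(Cl)cc3)nn2)C(OCc2ccccc2)=C1OCc1ccccc1` has not yet been measured. It differs from compound 1 by hydrogen in place of fluoro on an aromatic carbon. Among the compounds with values here, no step between measured compounds isolates this change, so the expectation rests on compound 1 alone, at 3390 nM. The step from compound 1 to compound 4 is expected to be small, a 1.3-fold higher number from compound 1 to compound 4 (0.12 log units; within the scatter), at or near the scatter, with a slight lean toward a higher number. Compound 4 is accordingly estimated at 4500 nM in this assay, within a range of 1500 nM to 14000 nM.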

Compound 4, half-maximal inhibitory concentration: 4170 nM
Beside the measured number, compound 4's estimate is 1.1-fold (0.03 log units) above it; the measured number falls inside the stated range.
By their numbers in this assay, from the lowest: compounds 1 and 4 (each within the scatter of the next); then compound 2. At a limit, above all of these: compound 3.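

In this assay, within the data shown here, hydrogen in place of fluoro on this aromatic carbon gives a 1.2-fold higher number from compound 1 to compound 4 (0.09 log units; within the scatter), the first step that isolates a change in one place. The 4-chloro-2-fluorophenyl and 4-chlorophenyl groups therefore cannot be told apart on this read-out, so the fluoro group at this position is not required for the level of inhibition seen with compound 1. No measurement shown bears on why this exchange leaves the read-out within the scatter.

The compounds shown leave open what a larger group on this aromatic carbon, such as methoxy or an amine, would do to the read-out. Also open, going by these compounds, is what hydrogen or a nitrile in place of the chloro group would do.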